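A Methyl for Chloro Swap at a Level Baseline

The source may hold more compounds than are shown below. What is called first, only, known or untested is meant among the compounds shown, and "the series" means these compounds.

Compound 1, with structure `CC(C)(C)Cc1csc(N)c1C(=O)c1ccc(Cl)cc1`, was tested in an assay on CHO cells for displacement of a labelled ligand from adenosine receptor A1 (Homo sapiens), read by scintillation counting, tested at 10 uM; a lower number here means less inhibition, a higher number more inhibition at the concentration tested (going by the name of the read-out). Compound 1 gives 1%, which is essentially no displacement at the concentration used. Compound 2, `CC(C)(C)Cc1c(-c2ccc(F)cc2)sc(N)c1C(=O)c1ccc(Cl)cc1`, differs from compound 1 by a 4-fluorophenyl in place of hydrogen on an aromatic carbon, and in this assay compound 2 gives 1%; the step of no change at the digits printed from compound 1 to compound 2 (within the scatter). Compound 1 therefore stands level with compound 2 at the digits shown, both at the floor of the read-out.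

Compound 3, `Cc1ccc(C(=O)c2c(CC(C)(C)C)csc2N)cc1`, has not been measured. The change from compound 1 to compound 3 is methyl in place of chloro on an aromatic carbon. Among the measured compounds shown here, no measured step touches this position; the only step available, no change at the digits printed from compound 1 to compound 2 (within the scatter), bears on it indirectly, showing that a sizable addition elsewhere on the shared core left the read-out unmoved. Since both measured compounds sit at the bottom of the scale, no step beyond the scatter is expected in this assay, and the expected change is a number 1 percentage points higher from compound 1 to compound 3 (within the scatter). Compound 3 is thus estimated at 2%, within a range from -8% to 12%.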

Compound 3, a percentage reported as inhibition, at one concentration (the size of the read-out at that concentration, not a potency): 1%
Compound 3: middle estimate off by 1 percentage points, on the high side; measured number inside the range.
By their numbers in this assay, from the lowest: compounds 1, 2 and 3 (each within the scatter of the next).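

In this assay, among the compounds shown here, the step at this position reads no change at the digits printed from compound 1 to compound 3 (within the scatter) and so gives the position a measured change of its own, where the earlier compounds offered only a change elsewhere on the shared core. The swap puts one heavy atom in place of one heavy atom on a six-membered aromatic ring of carbon only, para to a large group, with no ring, hydrogen-bond donor, hydrogen-bond acceptor or net charge entering or leaving. Compound 1 and compound 3 both read at the floor of the scale, which leaves no room to see a loss, so the result shows only that methyl does not lift the read-out off that floor where chloro did not, and no measurement at hand offers an explanation for this flat result.

As far as these compounds go, whether an amine or a carboxylic acid at this position, or a longer chain in place of the methyl, would raise the read-out remains open. From the compounds shown here alone, with all three compounds within the scatter of one another, it also remains open which parts of the shared core can move this read-out at all.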